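The source may hold more compounds than are shown below. What is called first, only, known or untested is meant among the compounds shown, and "the series" means these compounds.

Of the compounds shown here, two built on the same core have been tested in a functional assay on NCI-H460 cells (Homo sapiens) for cytotoxicity, read by sulforhodamine B assay, with a stated time of 48 h; a lower number here means a stronger inhibitor of growth, a higher number a weaker inhibitor of growth. Compound 1 `ClCc1ccccc1Cn1cnc2c(Cl)ncnc21` gives 44700 nM in this assay. Compound 2 `ClCc1cccc(Cn2cnc3c(Cl)ncnc32)c1` gives 36300 nM in this assay. Of the two numbers that of compound 2 is the lower one, but the two values lie within the scatter of each other, so nothing separates them beyond that.

Compound 3 `ClCc1cccc(Cn2cnc3c(Cl)nc(Cl)nc32)c1` has not yet been measured. Compared with compound 2 it carries chloro in place of hydrogen on an aromatic carbon, the added chloro sitting on the aromatic carbon between two ring nitrogen atoms of the core, meta to the chloro group already present. Among the compounds with values here, no step between two measured compounds of this kind has been recorded, so what this change does has to be judged from the change itself and from the narrow spread of the two known values. A small move toward a lower number in this assay is expected, of a size not clearly beyond the scatter; this expected step is a 1.3-fold lower number from compound 2 to compound 3 (0.11 log units; within the scatter). For compound 3 the expected value is 28000 nM, with a likely range from 9000 nM to 90000 nM.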

Compound 3, concentration for total growth inhibition: 6310 nM
Beside the measured number, compound 3's estimate is 4.4-fold (0.65 log units) above it; measured number below the stated range.
By their numbers in this assay, from the lowest: compound 3; then compounds 2 and 1 (each within the scatter of the next).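

In this assay, chloro in place of hydrogen on an aromatic carbon, between two ring nitrogen atoms of the core, gives a 5.8-fold lower number from compound 2 to compound 3 (0.76 log units; beyond the scatter), a step beyond the scatter. Within the data shown here, until this result, the measured compounds all carried the same unchanged core and their values lay within the scatter of each other, so this is the first sign that a single added atom at this position can move the number by more than the scatter. Nothing at hand explains why this substitution lowers the number, and a single step cannot show whether the same would hold elsewhere on the core.

Whether the lower number belongs to chloro in particular stays open, since no compound shown has an amine, a methoxy group or a methyl group on this same aromatic carbon. The compounds shown also leave open whether this added chloro would give a similar step on compound 1, where the benzyl substituent has a different arrangement, and what an amine would do in place of the other chloro on the core.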